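Moving the chlorine on a shared core: an untested step

The compounds below may be only part of what the source reports. "The series", "measured", "known", "first", "only" and "open" are said of these compounds alone.

Measured so far:
compound 1 `Oc1ccc(-c2cc(-c3ccccc3)nc(-c3ccccc3Cl)c2)cc1` — 3930 nM
compound 2 `Oc1ccc(-c2cc(-c3cccs3)nc(-c3ccccc3Cl)c2)cc1` — 5220 nM
compound 3 `Oc1ccc(-c2cc(-c3ccco3)nc(-c3ccccc3Cl)c2)cc1` — 4310 nM

All three numbers come from an ADME assay on HEK293 cells (Homo sapiens) for cytotoxicity, read by CCK-8 assay and cell counting, with a stated time of 2 days; on this read-out lower numbers stand for stronger inhibition and higher numbers for weaker inhibition. Compound 2 sits at the upper end of the three, yet the gaps that separate it from its neighbours, a 1.3-fold higher number from compound 1 to compound 2 (0.12 log units; within the scatter) and a 1.2-fold lower number from compound 2 to compound 3 (0.08 log units; within the scatter), are both within the scatter, as is a 1.1-fold higher number from compound 1 to compound 3 (0.04 log units; within the scatter). The three compounds therefore cannot be told apart on this read-out.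

Compound 4 `Oc1ccc(-c2cc(-c3cccc(Cl)c3)nc(-c3cccs3)c2)cc1` keeps the thiophen-2-yl group and the 4-hydroxyphenyl group of compound 2 and changes only the chlorinated ring: 3-chlorophenyl in place of 2-chlorophenyl on an aromatic carbon. Within the data shown here, none of the measured steps touches this ring; each swaps the group on the other side of the core, and each stays within the scatter. There is thus no direct evidence on moving the chlorine, and the only pattern seen is that small swaps of an aromatic group have left this assay unchanged.

On that basis the number for compound 4 is expected to stay close to that of compound 2, with a step of a 1.0-fold lower number from compound 2 to compound 4 (0.02 log units; within the scatter), which is no change beyond the scatter. The estimate for compound 4 is 5000 nM, ranging from 2400 nM to 10500 nM.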

Compound 4, half-maximal inhibitory concentration: 2720 nM
For compound 4 the middle estimate is 1.8-fold (0.26 log units) above the measured one, within the range that was stated.
By their numbers in this assay, from the lowest: compounds 4, 1, 3 and 2 (each within the scatter of the next).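

Moving the chlorine is the first change in this series made on the chlorinated ring itself, and the atoms stay the same while only their arrangement differs. Placing 3-chlorophenyl in place of 2-chlorophenyl next to the ring nitrogen gives (a 1.9-fold lower number from compound 2 to compound 4 (0.28 log units; within the scatter)), so compound 2 and compound 4 cannot be told apart in this assay, and within this pair the position of the chlorine on that ring has no effect that can be resolved from the scatter. Nothing shown here offers a measured explanation for how these two compounds read in this assay.

On these data alone, compound 1 and compound 3 carry only 2-chlorophenyl, so it remains open whether the same chlorine move would also leave the number unresolved with phenyl or furan-2-yl on the other side of the shared core. As far as these compounds go, it is also open whether replacing the chlorine on this ring with a different group, such as a methoxy group, an amine or a carboxylic acid, would produce a step beyond the scatter.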